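The source may hold more compounds than are shown below. What is called first, only, known or untested is meant among the compounds shown, and "the series" means these compounds.

Compound 1 `COc1ccc2c(c1)OC(c1cc(OC)c(OC)c(OC)c1)C(C(C)=O)=C2`, compound 2 `COc1ccc2c(c1)OC(c1cc(OC)c(OC)c(OC)c1)C(C(=O)O)=C2` and compound 3 `COc1ccc2c(c1)OC(c1cc(OC)c(OC)c(OC)c1)C(C(=O)Nc1ccccc1)=C2` share one core and differ only in the group on a carbonyl carbon. In a functional assay for inhibition of nuclear factor NF-kappa-B complex (Homo sapiens) (a higher number here means a weaker inhibitor, a lower number a stronger inhibitor), compound 1 gives 14100 nM, and compound 3 gives 17500 nM. For compound 2 the result is only a limit of the assay, > 50000 nM, so compound 2 sits at the weak end of these numbers (the limit of > 50000 nM in this assay, at which 1 of the 3 values shown sits). Compound 4 `COc1ccc2c(c1)OC(c1cc(OC)c(OC)c(OC)c1)C(C(=O)N(C)C)=C2` is not yet measured; it differs from compound 2 by dimethylamino in place of hydroxy on a carbonyl carbon. Going by the values given here, two measured steps bear on this change: an at least 3.5-fold higher number from compound 1 to compound 2 (0.54 log units; beyond the scatter) and an at least 2.8-fold lower number from compound 2 to compound 3 (0.45 log units; beyond the scatter). In the second of these, replacing the hydroxy brought the number down beyond the scatter, so a fall in this assay is expected, with compound 4 estimated at 18000 nM (range 8000 nM to 50000 nM). The expected step is then an at least 2.7-fold lower number from compound 2 to compound 4 (0.44 log units; beyond the scatter).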

Compound 4, half-maximal inhibitory concentration: > 50000 nM
Compound 4 ended at the assay's limit; the forecaster's own chance of this, stated with the estimate: 20%; middle value at least 2.7-fold (0.44 log units) from the limit.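

Compound 4 ends at a limit of this assay rather than at a number, so, with compound 2 at that limit too, the step between them cannot be read: the limit of > 50000 nM in this assay, at which 2 of the 4 values shown sit.

Having an amide on this carbonyl carbon is therefore not enough to keep a measurable value, since dimethylamino gives an at least 2.8-fold higher number from compound 3 to compound 4 (0.45 log units; beyond the scatter) and an at least 3.5-fold higher number from compound 1 to compound 4 (0.54 log units; beyond the scatter). Of the two amides shown, only the anilino compound 3 stays within the measurable range.

Still open, going by these compounds, is whether the ring of the anilino group or its amide hydrogen matters here. A methylamino or cyclohexylamino group on the same carbonyl carbon would help separate the two.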